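The compounds below may be only part of what the source reports. "The series", "measured", "known", "first", "only" and "open" are said of these compounds alone.

Measured so far in a functional assay on the whole organism with Homo sapiens as the target, read by hemolysis; on this read-out lower numbers stand for stronger inhibition and higher numbers for weaker inhibition:

Compound 1 `COc1cc(C=O)cc2c1CC(C)(C)O2`: 1100000 nM
Compound 2 `CC1(C)Cc2c(Oc3ccccc3)cc(C=O)cc2O1`: a limit of the assay, > 1120000 nM
Compound 3 `COc1cc(-c2nn[nH]n2)cc2c1CC(C)(C)O2`: 245000 nM

Compound 1 and compound 2 differ by phenyl in place of methyl on an oxygen on an aromatic ring. For compound 2 the assay reports only a limit, > 1120000 nM. The step is an at least 1.0-fold higher number from compound 1 to compound 2 (0.00 log units; that floor lies within the scatter), so on the core of compound 1 the exchange brought no gain; what the value of compound 2 shows beyond that is only that it sits at the limit of > 1120000 nM in this assay, at which 1 of the 3 values shown sits.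

Compound 1 and compound 3 differ by 2H-tetrazol-5-yl in place of formyl on an aromatic carbon. This step is a 4.5-fold lower number from compound 1 to compound 3 (0.65 log units; beyond the scatter), and compound 3 gives the lowest of the two numbers in this assay.

Compound 4 `CC1(C)Cc2c(Oc3ccccc3)cc(-c3nn[nH]n3)cc2O1` is not yet measured in this assay. It differs from compound 3 by phenyl in place of methyl on an oxygen on an aromatic ring, the same change as from compound 1 to compound 2, here made on the core of compound 3 rather than on the core of compound 1. Within the data shown here, the only precedent for this exchange is an at least 1.0-fold higher number from compound 1 to compound 2 (0.00 log units; that floor lies within the scatter), which gave no gain and leaves the size of any loss open. Resting on that step, the expected step from compound 3 to compound 4 is a 1.8-fold higher number from compound 3 to compound 4 (0.26 log units; within the scatter), a small loss rather than a gain. Compound 4 is therefore estimated at 450000 nM in this assay, expected to fall between 180000 nM and 1200000 nM, with a real chance that the assay again reports only a limit.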

Compound 4, half-maximal inhibitory concentration: 195000 nM
Estimate against measurement, compound 4: 2.3-fold (0.36 log units) above; low and high end bracket the measured number.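

In this assay, phenyl in place of methyl on the core of compound 3 gives a 1.3-fold lower number from compound 3 to compound 4 (0.10 log units; within the scatter), so methoxy to phenoxy brings no step beyond the scatter on this core, and the comparison with the earlier core reads: the same change on two cores in this assay, an at least 1.0-fold higher number (0.00 log units; that floor lies within the scatter) from compound 1 to compound 2 and a 1.3-fold lower number (0.10 log units; within the scatter) from compound 3 to compound 4; the limit leaves it open whether they differ

The other exchange, 2H-tetrazol-5-yl in place of formyl, now gives an at least 5.7-fold lower number from compound 2 to compound 4 (0.75 log units; beyond the scatter) on the phenoxy core, and the comparison with the methoxy core reads: the same change on two cores in this assay, a 4.5-fold lower number (0.65 log units; beyond the scatter) from compound 1 to compound 3 and an at least 5.7-fold lower number (0.75 log units; beyond the scatter) from compound 2 to compound 4; the limit leaves it open whether they differ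

Compound 2 is reported only as a limit of the assay, > 1120000 nM, so the two pairs show a lower number with 2H-tetrazol-5-yl on both cores, but they do not show whether either change has the same size on the two cores.

The compounds shown leave open whether a carboxylic acid or a nitrile on the same aromatic carbon would also lower the number, so the step cannot yet be tied to 2H-tetrazol-5-yl in particular. Among these compounds, they also leave open how a longer chain or a benzyl group on the oxygen would read in this assay, since methyl and phenyl are the only two groups compared at that place.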